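Rearranged five-membered ring: outlook for compound 3

This account rests on a few compounds, and the source may have more. Where it says the series, first, only, none or still open, it means among the compounds named here.

Measured compounds:
- compound 1 `CC1=C(O)[C@H](C/C(C)=C\CC[C@H](C)/C=C/C=C(\C)CCCC2=CCN(CCC(C)C)C2=O)OC1=O`; in a functional assay on SK-OV-3 cells (Homo sapiens) for cytotoxicity (on this read-out higher numbers stand for an effect only at larger amounts of compound and lower numbers for an effect already at smaller amounts), compound 1 gives 5.3 ug/mL
- compound 2 `CCC(C)CN1CC=C(CCC/C(C)=C/C=C/[C@@H](C)CC/C=C(/C)C[C@@H]2OC(=O)C(C)=C2O)C1=O`; in this assay compound 2 gives 6.9 ug/mL

Of the two numbers, compound 2 carries the highest, yet its step from compound 1 stays within the scatter: a 1.3-fold higher number from compound 1 to compound 2 (0.11 log units; within the scatter). Compound 3 `CC1=C(O)[C@H](C/C(C)=C\CC[C@H](C)/C=C/C=C(\C)CCCC2=CC(=O)N(CCC(C)C)C2)OC1=O` differs from compound 2 by a group of 11 heavy atoms (9 carbon, 1 nitrogen, 1 oxygen; one five-membered non-aromatic ring with 1 hetero atom) in place of a group of 11 heavy atoms (9 carbon, 1 nitrogen, 1 oxygen; one five-membered non-aromatic ring with 1 hetero atom), on a saturated chain carbon, three bonds along the chain from a double-bonded chain carbon. Within the data shown here, no measured step covers a change of this kind; the single step, a 1.3-fold higher number from compound 1 to compound 2 (0.11 log units; within the scatter), concerns only the sec-butyl in place of isobutyl on a saturated chain carbon bound to an amide-type nitrogen in a ring, and it is within the scatter. For compound 3 in this assay no step beyond the scatter is therefore expected, with a wide range. The estimate for compound 3 is 6.5 ug/mL (range 2.2 ug/mL to 19 ug/mL). This expected estimate means a step of a 1.1-fold lower number from compound 2 to compound 3 (0.03 log units; within the scatter).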

Compound 3, concentration for half-maximal effect: 25.9 ug/mL
For compound 3 the middle estimate is 4.0-fold (0.60 log units) below the measured one; the measured number lies above the stated range.
By their numbers in this assay, from the lowest: compounds 1 and 2 (each within the scatter of the next); then compound 3.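

In this assay, the same atoms joined differently in the five-membered non-aromatic ring with 1 hetero atom give a 3.8-fold higher number from compound 2 to compound 3 (0.57 log units; beyond the scatter) and a 4.9-fold higher number from compound 1 to compound 3 (0.69 log units; beyond the scatter) with the number moving the same way in both. This place on the saturated chain carbon therefore responds to how the ring is joined, with no change in atom count, a response that the sec-butyl for isobutyl step did not show. Nothing at hand accounts for the shift. Open, on these data alone, is how an open-chain amine or a carboxylic acid in place of this ring would read.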